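The source may report more compounds than this note shows. Statements on the series, on what has been measured and on what is new or still open speak of the compounds shown alone.

Compound 1 `C=C(CC/C=C(\C)CCC=C(C)C)C(O)Cc1c(O)cc(C)c(C=O)c1O`, compound 2 `C=C(CCC1CCCCC1)C(O)Cc1c(O)cc(C)c(C=O)c1O` and compound 3 `C=C(CC[C@@]1(C)[C@H](C)CCC(=O)[C@@H]1C)[C@H](O)Cc1c(O)cc(C)c(C=O)c1O` share one core. In an ADME assay on EC17 cells (Homo sapiens) for cytotoxicity, read by trypan blue exclusion (on this read-out lower numbers stand for stronger inhibition and higher numbers for weaker inhibition), compound 2 gives 87000 nM. Compound 1 reaches only a limit of the assay, > 80000 nM. Compound 3 likewise reaches only a limit, > 77000 nM. Compound 2 therefore holds the only number shown; the two other values are limits. Compound 4 `C=C(CCc1c(C)cccc1C)C(O)Cc1c(O)cc(C)c(C=O)c1O` differs from compound 2 by 2,6-dimethylphenyl in place of cyclohexyl on a saturated chain carbon, two bonds along the chain from a double-bonded chain carbon. Among the measured compounds shown here, the one measured step at this place, a step that the limit leaves unreadable from compound 1 to compound 2, cannot be read in size because of the limit of > 80000 nM in this assay, at which 1 of the 3 values shown sits. Nothing here points to a change beyond the scatter. Compound 4 is therefore expected to give about 85000 nM, within a range from 40000 nM to 180000 nM. This amounts to an expected step of a 1.0-fold lower number from compound 2 to compound 4 (0.01 log units; within the scatter).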

Compound 4, half-maximal inhibitory concentration: 45000 nM
The estimate for compound 4 lay 1.9-fold (0.28 log units) above the measured number, and the stated range covers the measured number.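

In this assay, among the compounds shown here, 2,6-dimethylphenyl in place of cyclohexyl gives the first step at this place that can be read in size: a 1.9-fold lower number from compound 2 to compound 4 (0.29 log units; within the scatter). An aromatic ring and a non-aromatic ring therefore cannot be told apart here on these two compounds alone. Against 2,6-dimethylhepta-1,5-dien-1-yl there is an at least 1.7-fold lower number from compound 1 to compound 4 (0.24 log units; that floor lies within the scatter), and this size is only a floor, set by a limit: the limit of > 80000 nM in this assay, at which 1 of the 4 values shown sits.

The compounds shown leave open whether an amine or a carboxylic acid on this chain would move the number beyond the scatter.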